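A few compounds are considered here, and "the series" means these few. Any claim that something is new, unique, unknown or untested is made for them only; others in the source may bear on it.

In a physicochemical assay for solubility (on this read-out lower numbers stand for lower solubility and higher numbers for higher solubility), two compounds sharing one core have been read so far. Compound 1 `O=C(c1nc2c(C(F)(F)F)cc(-c3ccoc3)cn2c1Cl)N1CCC(c2ccccc2F)C1` gives < 15000 nM, which is a limit of the assay and not a number. Compound 2 `O=C(c1nc2c(C(F)(F)F)cc(-c3ccoc3)cn2c1Cl)N1CCC(c2cccs2)C1` gives < 15000 nM, which is also a limit. Compound 2 therefore has no exact place on the scale, only (the limit of < 15000 nM in this assay, at which 2 of the 2 values shown sit).

The next compound, compound 3 `CN1CCN(C(=O)c2nc3c(C(F)(F)F)cc(-c4ccoc4)cn3c2Cl)CC1=O`, keeps the shared core but exchanges the whole group on the carbonyl carbon: a group of 8 heavy atoms (5 carbon, 2 nitrogen, 1 oxygen; one six-membered non-aromatic ring with 2 hetero atoms) in place of a group of 10 heavy atoms (8 carbon, 1 nitrogen, 1 sulfur; one five-membered non-aromatic ring with 1 hetero atom, one five-membered aromatic ring with 1 hetero atom), on a carbonyl carbon. Among the compounds with values here, the one measured step that bears on this is a step that the two limits leave unreadable from compound 1 to compound 2, with thiophen-2-yl in place of 2-fluorophenyl on a saturated ring carbon. That step has no readable size, and it lies within the group that now leaves, so it offers no measured guide to how far this assay should move. A modest rise is expected, but this is a loose judgement resting on the structural change alone. The estimated size of this move is an at least 1.6-fold higher number from compound 2 to compound 3 (0.22 log units; that floor lies within the scatter). For compound 3, the expected value is 25000 nM, within an estimated range from 8000 nM to 80000 nM.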

Compound 3, solubility: > 500000 nM
Compound 3: no number, only a limit; the forecaster's own chance of this, stated with the estimate: 45%; middle value at least 20-fold (1.30 log units) away from the limit.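

In this assay, the group on the carbonyl carbon turns out to be able to move the read-out a long way, with an at least 33-fold higher number from compound 2 to compound 3 (1.52 log units; beyond the scatter), and this step lies beyond the scatter. Compound 3 gives > 500000 nM, which is a limit of the assay and not a number. The earlier change, thiophen-2-yl in place of 2-fluorophenyl on a saturated ring carbon, cannot be read, because both of its ends sit at the same limit, so exchanging the whole group on the carbonyl carbon gives the first step in this series with even a minimum size: the limit of < 15000 nM in this assay, at which 2 of the 3 values shown sit.

The whole group changed in a single move, so the compounds shown do not separate what the 4-methyl-3-oxopiperazin-1-yl group itself contributes from what goes with the departure of the five-membered aromatic ring. A morpholine or a 4-methylpiperazin-1-yl group on the same carbonyl carbon would begin to show which part of the entering group goes with the step.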